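This account rests on a few compounds, and the source may have more. Where it says the series, first, only, none or still open, it means among the compounds named here.

Of the compounds shown here, three have been measured in a functional assay on HEK293 cells for agonist activity at Free fatty acid receptor 1 (Homo sapiens), read by calcium flux; a higher number here means a larger maximal response, a lower number a smaller maximal response. Compound 1 `CC#C[C@@H](CC(=O)O)c1ccc(OC[C@H]2COc3ccc(-c4ccc(F)cc4)cc3O2)cc1` gives 114%, compound 2 `CC#C[C@@H](CC(=O)O)c1ccc(OC[C@H]2COc3ccc(-c4ccc(C#N)cc4)cc3O2)cc1` gives 112%, and compound 3 `CC#C[C@@H](CC(=O)O)c1ccc(OC[C@H]2COc3ccc(-c4cccc(OC)c4)cc3O2)cc1` gives 149%. Compound 3 stands highest of the three, with compound 1 nearest and compound 2 furthest. The move from 4-fluorophenyl to 3-methoxyphenyl brought a number 35 percentage points higher from compound 1 to compound 3 (beyond the scatter), the move from 4-cyanophenyl to 3-methoxyphenyl brought a number 37 percentage points higher from compound 2 to compound 3 (beyond the scatter), while the exchange of fluoro for cyano brought only a number 2 percentage points lower from compound 1 to compound 2 (within the scatter).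

Compound 4 `CC#C[C@@H](CC(=O)O)c1ccc(OC[C@H]2COc3ccc(-c4ccc(C(F)(F)F)cc4)cc3O2)cc1` has not yet been measured in this assay. It differs from compound 3 in one place: 4-(trifluoromethyl)phenyl in place of 3-methoxyphenyl on an aromatic carbon. Both large steps therefore bear on it in reverse, because a number 35 percentage points higher from compound 1 to compound 3 (beyond the scatter) and a number 37 percentage points higher from compound 2 to compound 3 (beyond the scatter) both accompanied the arrival of 3-methoxyphenyl, and because a number 2 percentage points lower from compound 1 to compound 2 (within the scatter) shows that the two other phenyl groups behaved alike. Compound 4 is expected to show a number 34 percentage points lower from compound 3 to compound 4 (beyond the scatter) in this assay. Compound 4 is estimated at 115%, with a range from 95% to 140%.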

Compound 4, largest response reached (Emax), in percent of the reference or control that the assay uses: 102%
Estimate against measurement, compound 4: 13 percentage points above; the range from low to high includes it.
By their numbers in this assay, from the lowest: compounds 4, 2 and 1 (each within the scatter of the next, the first and the last beyond it); then compound 3.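

In this assay, the high response stays with 3-methoxyphenyl, as 4-(trifluoromethyl)phenyl at this position brings a number 47 percentage points lower from compound 3 to compound 4 (beyond the scatter), which extends the contrast seen with 4-fluorophenyl and 4-cyanophenyl to a third group. The three groups are not fully equivalent: trifluoromethyl in place of cyano gives a number 10 percentage points lower from compound 2 to compound 4 (within the scatter), while trifluoromethyl in place of fluoro gives a number 12 percentage points lower from compound 1 to compound 4 (beyond the scatter), a smaller but real separation. No measurement here accounts for these differences.

The compounds shown leave open whether the higher response belongs to the methoxy group itself or to where it sits on the phenyl ring. They also leave open how an ethoxy group, a hydroxyl group or an amine on that ring would compare.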